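Formyl for Ethyl on the Phenyl Ring of Compound 2

This account rests on a few compounds, and the source may have more. Where it says the series, first, only, none or still open, it means among the compounds named here.

Measured so far:
compound 1 `c1cn2cc(-c3ccsc3)nc(-c3ccc4ncn(C5CCCCC5)c4c3)c2n1`: 18.5%
compound 2 `CCc1ccc(-c2cn3ccnc3c(-c3ccc4ncn(Cc5ccccc5)c4c3)n2)cc1`: 39.6%

Of the compounds shown here, two have been measured in a functional assay on HL-60 cells (Homo sapiens) for inhibition, read by sulforhodamine B assay, with a stated time of 48 h, tested at 10 uM; a higher number here means more inhibition at the concentration tested (going by the name of the read-out), a lower number less inhibition. Compound 1 `c1cn2cc(-c3ccsc3)nc(-c3ccc4ncn(C5CCCCC5)c4c3)c2n1` gives 18.5% in this assay. Compound 2 `CCc1ccc(-c2cn3ccnc3c(-c3ccc4ncn(Cc5ccccc5)c4c3)n2)cc1` gives 39.6%, the higher of the two numbers; its gap to compound 1 lies beyond the scatter. Compound 1 and compound 2 differ in more than one place, so the pair shows only the two values side by side.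

Compound 3 `O=Cc1ccc(-c2cn3ccnc3c(-c3ccc4ncn(Cc5ccccc5)c4c3)n2)cc1` has not yet been measured. It differs from compound 2 in one place: formyl in place of ethyl on an aromatic carbon. For the measured compounds named here, no step of this exact kind is available among the measured pair, so its size in this assay is unknown. With this in mind, the estimate is that the step of a number 4.6 percentage points lower from compound 2 to compound 3 (within the scatter) is expected to stay within the usual scatter. Compound 3 is thus expected at 35%, with a range from 15% to 60%.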

Compound 3, a percentage reported as inhibition, at one concentration (the size of the read-out at that concentration, not a potency): 16.5%
Beside the measured number, compound 3's estimate is 18.5 percentage points above it, within the range that was stated.
By their numbers in this assay, from the lowest: compounds 3 and 1 (each within the scatter of the next); then compound 2.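

In this assay, the change from ethyl to formyl on an aromatic carbon, para to a large group, gives a number 23.1 percentage points lower from compound 2 to compound 3 (beyond the scatter), so the number at this position depends on which group it carries, even though both groups have the same heavy-atom count. The change replaces a carbon with an oxygen and adds a hydrogen-bond acceptor and a double bond outside aromatic rings, and this single step cannot separate these differences from one another. No measurement shown here explains the lower number.

From the compounds shown here alone, it remains open whether a carboxylic acid, an amine or a longer chain at this position would give a number closer to that of compound 2 or of compound 3. Going by these compounds, whether the step would carry over to another compound also remains open.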